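Series notes: carbonyl variant of compound 1 awaiting measurement

A few compounds are considered here, and "the series" means these few. Any claim that something is new, unique, unknown or untested is made for them only; others in the source may bear on it.

Measured so far:
compound 1, `Cc1nnc(CN2CCCC2)n1-c1ccc(Cl)cc1Cc1ccccc1`, gives 36 mg/kg in a functional assay on the whole organism (strain CF-1) for inhibition, with Mus musculus as the target; on this read-out lower numbers stand for an effect already at smaller amounts and higher numbers for an effect only at larger amounts of compound
compound 2, `Cc1nnc(CN)n1-c1ccc(Cl)cc1C(O)c1ccccc1`, gives 1.6 mg/kg in this assay
compound 3, `Cc1nnc(CN(C)C)n1-c1ccc(Cl)cc1C(=O)c1ccccc1`, gives 0.5 mg/kg in this assay

Compound 1 stands highest of the three numbers; compound 2 and compound 3 both lie well below it, each gap beyond the scatter. Compound 4, `Cc1nnc(CN2CCCC2)n1-c1ccc(Cl)cc1C(=O)c1ccccc1Cl`, differs from compound 1 by (2-chlorophenyl)carbonyl in place of benzyl on an aromatic carbon. For the measured compounds named here, no step between measured compounds covers this change alone, and compounds 2 and 3 also differ from compound 1 at the amine. Still, because compound 3 with its carbonyl gives 0.5 mg/kg, a downward step beyond the scatter is expected, a 12-fold lower number from compound 1 to compound 4 (1.08 log units; beyond the scatter). Compound 4 is estimated at 3 mg/kg, with a range from 0.8 mg/kg to 12 mg/kg.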

Compound 4, dose for half-maximal effect: 1.8 mg/kg
Beside the measured number, compound 4's estimate is 1.7-fold (0.22 log units) above it, within the range that was stated.
By their numbers in this assay, from the lowest: compound 3; then compounds 2 and 4 (each within the scatter of the next); then compound 1.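

In this assay, this aromatic carbon of compound 1 tolerates more than benzyl: (2-chlorophenyl)carbonyl in its place, with the amine unchanged, gives a 20-fold lower number from compound 1 to compound 4 (1.30 log units; beyond the scatter). For the compounds shown here, this is the first reading of a change at this position alone, and the step is large. Nothing on hand accounts for the step.

The swap brings in the carbonyl and the chlorine together, so their shares remain unseparated. Open too, from the compounds shown here alone, is how (2-fluorophenyl)carbonyl or (2-methylphenyl)carbonyl would read with the same amine.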